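Amide Group Variation in a Cytotoxicity Series

The source may report more compounds than this note shows. Statements on the series, on what has been measured and on what is new or still open speak of the compounds shown alone.

compound 1 `CN1[C@@H]2c3[nH]c4ccccc4c3C[C@H]1[C@H](C#N)N1[C@@H](CNC(=O)c3ccc(Cl)cc3)c3[nH]c4ccccc4c3C[C@@H]21` — in a functional assay on HCT-116 cells (Homo sapiens) for cytotoxicity, read by MTT assay, with a stated time of 72 h (on this read-out lower numbers stand for stronger inhibition and higher numbers for weaker inhibition), compound 1 gives 630 nM
compound 2 `COc1ccc(C(=O)NC[C@H]2c3[nH]c4ccccc4c3C[C@H]3[C@H]4c5[nH]c6ccccc6c5C[C@@H]([C@H](C#N)N23)N4C)cc1` — compound 2 gives 430 nM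
compound 3 `CN1[C@@H]2c3[nH]c4ccccc4c3C[C@H]1[C@H](C#N)N1[C@@H](CNC(=O)c3ccc4ccccc4n3)c3[nH]c4ccccc4c3C[C@@H]21` — compound 3 gives 240 nM

Compound 3 holds the lowest of the three numbers; its gap to compound 2 is within the scatter, whereas the step of a 2.6-fold lower number from compound 1 to compound 3 (0.42 log units; beyond the scatter) lies beyond it. Compound 4 `CN1[C@@H]2c3[nH]c4ccccc4c3C[C@H]1[C@H](C#N)N1[C@@H](CNC(=O)/C=C/c3cccc(C(F)(F)F)c3)c3[nH]c4ccccc4c3C[C@@H]21` differs from compound 3 in one place: 2-(3-(trifluoromethyl)phenyl)ethenyl in place of quinolin-2-yl on a carbonyl carbon. Every step measured so far swaps the group on this same carbonyl carbon: a 1.5-fold lower number from compound 1 to compound 2 (0.17 log units; within the scatter), a 2.6-fold lower number from compound 1 to compound 3 (0.42 log units; beyond the scatter) and a 1.8-fold lower number from compound 2 to compound 3 (0.25 log units; within the scatter). These steps were modest at most, so for compound 4 a modest step toward a higher number is expected in this assay, namely a 1.7-fold higher number from compound 3 to compound 4 (0.22 log units; within the scatter). Compound 4 is therefore estimated at 400 nM, with a range from 150 nM to 1200 nM.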

Compound 4, half-maximal inhibitory concentration: 610 nM
Compound 4: middle estimate off by 1.5-fold (0.18 log units), on the low side, within the range that was stated.
By their numbers in this assay, from the lowest: compounds 3, 2, 4 and 1 (each within the scatter of the next, the first and the last beyond it).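

In this assay, among these compounds, the carbonyl carbon carries a group with a double bond outside aromatic rings for the first time, and 2-(3-(trifluoromethyl)phenyl)ethenyl loses the gain seen with quinolin-2-yl, giving a 2.5-fold higher number from compound 3 to compound 4 (0.41 log units; beyond the scatter) at this position. Both a 1.4-fold higher number from compound 2 to compound 4 (0.15 log units; within the scatter) and a 1.0-fold lower number from compound 1 to compound 4 (0.01 log units; within the scatter) lie within the scatter, so the new group cannot be told apart from 4-methoxyphenyl or 4-chlorophenyl. Quinolin-2-yl thus stands apart from 4-chlorophenyl and the new group, but not from 4-methoxyphenyl.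

No measurement here explains these differences. Going by these compounds, how an aminomethyl group or a carboxylic acid on the aromatic ring would fare at this carbonyl carbon remains open.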